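Chloro in place of hydrogen on compound 2

The source may report more compounds than this note shows. Statements on the series, on what has been measured and on what is new or still open speak of the compounds shown alone.

In a physicochemical assay for lipophilicity, at pH 7.4 (on this read-out higher numbers stand for higher lipophilicity and lower numbers for lower lipophilicity), compound 1 (`Cc1cc(-c2nc3ccccc3s2)ccc1N`) gives 2.51 and compound 2 (`O=S(=O)(O)Nc1ccc(-c2nc3ccccc3s2)cc1`) gives 7.5 as the higher of the two numbers, a gap beyond the scatter. The step to compound 3 (`O=S(=O)(O)Nc1ccc(-c2nc3ccccc3s2)cc1Cl`) is chloro in place of hydrogen on an aromatic carbon on an aromatic carbon ortho to a sulfoamino group, chloro in place of hydrogen. Among the compounds with values here, no measured pair shows this change. In this assay a small rise is expected, estimated as a number 0.40 log units higher from compound 2 to compound 3 (beyond the scatter) and resting on the structural change alone. Compound 3 is expected at 7.9 within an estimated range from 7.1 to 8.7 on these two numbers.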

Compound 3, distribution coefficient: < 2.19
Compound 3: only a limit was reported; the forecaster's own chance of this, stated with the estimate: 5%; middle value at least 5.71 log units away from the limit.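

In this assay, chloro in place of hydrogen on an aromatic carbon ortho to a sulfoamino group gives a large step, a number at least 5.31 log units lower from compound 2 to compound 3 (beyond the scatter). Within the data shown here, the earlier compounds offered no step between them, so this is the first sign that a single change at this position can move the read-out this far. Compound 3 gives < 2.19, which is a limit and not a number, so the full size of the step stays unfixed: the limit of < 2.19 in this assay, at which 1 of the 3 values shown sits.

The compounds shown leave open whether fluoro or methoxy at this carbon moves the read-out the same way. On these data alone, whether chloro does so with an amine in place of the sulfoamino group also stays open.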